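A piperidin-2-yl swap on compound 3

The source may hold more compounds than are shown below. What is called first, only, known or untested is meant among the compounds shown, and "the series" means these compounds.

Measured in an ADME assay on the whole organism (strain CD) for metabolic stability, with Rattus norvegicus as the target, at a dose of 1 mg/kg by the intravenous route; on this read-out lower numbers stand for a shorter-lived compound and higher numbers for a longer-lived compound:
Compound 1 `CC(=O)NCc1cccc(Cn2nc(NS(=O)(=O)c3ccc(Cl)s3)c3c(O)cccc32)c1`: 1.2 h
Compound 2 `CC(=O)NCc1cccc(Cn2nc(NS(=O)(=O)c3ccc(Cl)s3)c3c(C(C)O)cccc32)c1`: 3.7 h
Compound 3 `CN[C@H](C)C(=O)NCc1cccc(Cn2nc(NS(=O)(=O)c3ccc(Cl)s3)c3c(OC)cccc32)c1`: 0.8 h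

Compound 3 and compound 1 lie within the scatter of each other, and compound 2 lies beyond the scatter from both, at the longer-lived end. Compound 4 `COc1cccc2c1c(NS(=O)(=O)c1ccc(Cl)s1)nn2Cc1cccc(CNC(=O)[C@@H]2CCCCN2)c1` differs from compound 3 in one place: piperidin-2-yl in place of 1-(methylamino)ethyl on a carbonyl carbon. For the measured compounds named here, the only measured step, a 3.1-fold higher number from compound 1 to compound 2 (0.49 log units; beyond the scatter), concerns a group on an aromatic carbon, not this carbonyl carbon, so it says nothing direct about the change. No step beyond the scatter is therefore expected in this assay, and the expectation starts from compound 3 at 0.8 h. The expected step is a 1.3-fold higher number from compound 3 to compound 4 (0.10 log units; within the scatter). Compound 4 is estimated at 1 h, with an expected range of 0.5 h to 2 h.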

Compound 4, half-life: 3 h
Compound 4: middle estimate off by 3.0-fold (0.48 log units), on the low side; measured number above the stated range.
By their numbers in this assay, from the lowest: compounds 3 and 1 (each within the scatter of the next); then compounds 4 and 2 (each within the scatter of the next).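

In this assay, the group on the carbonyl carbon proves able to move the half-life: piperidin-2-yl in place of 1-(methylamino)ethyl gives a 3.8-fold higher number from compound 3 to compound 4 (0.57 log units; beyond the scatter). For the compounds shown here, until now, the only step beyond the scatter concerned a group on an aromatic carbon. Nothing shown here accounts for this step.

The two compounds cannot separate the effect of the ring from that of the larger group. Going by these compounds, how a pyrrolidin-2-yl group or an open-chain 1-(dimethylamino)ethyl group would behave on this carbonyl carbon also remains open.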